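The source may report more compounds than this note shows. Statements on the series, on what has been measured and on what is new or still open speak of the compounds shown alone.

Measured in a functional assay on L1210 cells (Mus musculus) for inhibition, with a stated time of 48 h; on this read-out higher numbers stand for weaker inhibition and lower numbers for stronger inhibition:
Compound 1 `CCNCCCNCCCNCC`: > 100000 nM
Compound 2 `CCCNCCCNCCCNCCC`: > 100000 nM
Compound 3 `CCNCCCCNCCCN`: > 100000 nM

All three entries are limits of this assay, not numbers. Among the compounds with values here, the series so far offers (the limit of > 100000 nM in this assay, at which 3 of the 3 values shown sit), so no measured potency anchors it. Compound 2 stands at > 100000 nM, and this is a limit.

The next compound is compound 4 `CCCNCCCCNCCCNCCC`. The change from compound 2 is (propylamino)methyl in place of propylamino on a saturated chain carbon, three bonds along the chain from an amine nitrogen. Within the data shown here, no measured step shows what such a change does.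

No shift beyond the usual scatter is expected in this assay, and no direction can be assigned. This expectation rests on compound 2 at > 100000 nM, a limit. The most likely outcome is that the assay again reports only a limit. The expected step is a number no higher from compound 2 to compound 4 (the limit leaves the size open). Compound 4 is estimated at 100000 nM, with an expected range from 30000 nM to 150000 nM.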

Compound 4, half-maximal inhibitory concentration: > 100000 nM
Compound 4 gave a limit, no number; the forecaster's own chance of this, stated with the estimate: 75%; the middle value sits exactly at the limit.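

Compound 2 and compound 4 both give only limits, so no step can be read between them. The compounds shown leave open what (propylamino)methyl in place of propylamino does to inhibition, and no measured potency yet anchors the series, which rests entirely on one limit: the limit of > 100000 nM in this assay, at which 4 of the 4 values shown sit.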